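Changing an ester to a ketone on a cytotoxicity readout

The source may report more compounds than this note shows. Statements on the series, on what has been measured and on what is new or still open speak of the compounds shown alone.

Measured so far:
- compound 1 `COC(=O)c1sccc1NC(=O)CSc1nncnc1-c1ccccc1Cl`: 105000 nM
- compound 2 `COC(=O)c1ccc(NC(=O)CSc2nncnc2-c2ccccc2Cl)c(Br)c1`: 59000 nM
- compound 3 `O=C(CSc1nncnc1-c1ccccc1Cl)Nc1ccccc1`: 127000 nM

All three share one core and differ only in the group on the amide-type nitrogen. In an ADME assay on MT4 cells (Homo sapiens) for cytotoxicity, read by MTT assay (a lower number here means that less compound is tolerated, a higher number that more compound is tolerated), compound 2 gives the lowest of the three numbers; the gap to compound 1 lies within the scatter, the gap to compound 3 beyond it. For the measured compounds named here, the one single-point step in the set, a 1.2-fold higher number from compound 1 to compound 3 (0.08 log units; within the scatter), changes the whole aryl group on the nitrogen and stays within the scatter.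

Compound 4 `CC(=O)c1ccc(NC(=O)CSc2nncnc2-c2ccccc2Cl)c(Br)c1` keeps everything of compound 2 except one group: methyl in place of methoxy on a carbonyl carbon. Going by the values given here, no measured step touches this carbonyl carbon, so the only guide is that every change seen so far, including the large one in the step from compound 1 to compound 3, has moved this assay little. The step is therefore expected to be a 1.0-fold higher number from compound 2 to compound 4 (0.01 log units; within the scatter), with no direction that goes beyond the scatter. For compound 4 the estimate is 60000 nM, with a range from 30000 nM to 120000 nM.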

Compound 4, half-maximal cytotoxic concentration: 34000 nM
Compound 4: the middle estimate sits 1.8-fold (0.25 log units) above what was measured; the range from low to high includes it.
By their numbers in this assay, from the lowest: compounds 4, 2, 1 and 3 (each within the scatter of the next, the first and the last beyond it).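

For the compounds shown here, this is the first change made at the carbonyl carbon itself, and in this assay methyl in place of methoxy gives a 1.7-fold lower number from compound 2 to compound 4 (0.24 log units; within the scatter) which stays within the normal scatter of the measurement. Compound 2 and compound 4 therefore cannot be told apart here, so on this one aryl group, methoxycarbonyl and acetyl are interchangeable as far as this readout can show. No supporting evidence is available to explain the step.

From the compounds shown here alone, it remains open whether a carboxylic acid, a primary amide or a ketone with a longer chain in place of the methoxycarbonyl would also stay this close to compound 2. Going by these compounds, it is also open whether the same change from methoxycarbonyl to acetyl would behave alike in compound 1, which carries its methoxycarbonyl on a different aryl group.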